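The compounds below may be only part of what the source reports. "The series", "measured", "known", "first", "only" and "open" are said of these compounds alone.

Working notes on four compounds bearing an ethoxy-imine amidine.

Compound 1 `CCO/N=C/Nc1cc(Cl)c(OCC#N)c(Cl)c1` and compound 2 `CCO/N=C/Nc1cc(Cl)c(OCOC)c(Cl)c1` share one core and differ at a single point: methoxy in place of cyano on a saturated chain carbon bound to an oxygen on an aromatic ring. In a physicochemical assay for lipophilicity, measured as octanol-water partition (on this read-out lower numbers stand for lower lipophilicity and higher numbers for higher lipophilicity), compound 1 gives 3.1, and compound 2 gives 3.7. The step is a number 0.60 log units higher from compound 1 to compound 2 (beyond the scatter).

Compound 3 `C#CCc1c(Cl)cc(N/C=N/OCC#N)cc1Cl` carries a second core; how it differs from the core of compound 1 is not broken down here. In this assay compound 3 gives 3, which stands alongside the value of compound 1 and some way under that of compound 2.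

Compound 4 `C#CCc1c(Cl)cc(N/C=N/OCOC)cc1Cl` is not yet measured. It stands to compound 3 as compound 2 stands to compound 1: methoxy in place of cyano on a saturated chain carbon bound to an oxygen. The two places are not the same word for word: in the pair from compound 1 to compound 2 the saturated chain carbon is bound to an oxygen on an aromatic ring, whereas in the pair from compound 3 to compound 4 it is bound to an oxygen only. Among the compounds with values here, the change is therefore the same kind of change, not the same change, and the single measured example gives the only footing.

From compound 3 to compound 4 a step of about a number 0.60 log units higher from compound 3 to compound 4 (beyond the scatter) in this assay is expected, resting on the step from compound 1 to compound 2 a number 0.60 log units higher from compound 1 to compound 2 (beyond the scatter). On that basis compound 4 is estimated at 3.6, with a range from 3.3 to 3.9.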

Compound 4, partition coefficient: 3.2
Beside the measured number, compound 4's estimate is 0.40 log units above it, and the stated range ends above it.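

On the core of compound 3 the step in this assay is a number 0.20 log units higher from compound 3 to compound 4 (within the scatter), whereas on the core of compound 1 it is a number 0.60 log units higher from compound 1 to compound 2 (beyond the scatter), so the same kind of change does not bring the same size of step on these two cores. Within the data shown here, this shows that the step on the core of compound 1 cannot be carried over as a fixed increment to the core of compound 3, but with only one pair on each core it does not show how the change behaves across the series, and it gives no rule for any other core. No measurement at hand bears on why the two steps differ.

The compounds shown leave open whether the step on a further core would resemble the one from the core of compound 1 or the one from the core of compound 3. They also leave open how an amine, a carboxylic acid or a longer chain in place of cyano or methoxy, on a saturated chain carbon bound to an oxygen, would read out on either core.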